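The compounds below may be only part of what the source reports. "The series", "measured", "known", "first", "only" and "open" are said of these compounds alone.

Working notes on the series in a functional assay on CHO cells with adenosine receptor A1 (Homo sapiens) as the target, read by cAMP accumulation and immunoassay, with a stated time of 6 min, tested at 0.01 uM; a higher number here means a weaker effect of the compound at the concentration tested, a lower number a stronger effect. Among the compounds with values here, compound 1 `Nc1scc(CN2CCN(c3ccc(OC(F)(F)F)cc3)CC2)c1C(=O)c1ccc(Cl)cc1` gives 0%, the lowest of the three numbers so far. Compound 2 `Nc1scc(CN2CCN(c3cccnc3)CC2)c1C(=O)c1ccc(Cl)cc1` gives 3.2% and compound 3 `Nc1scc(CN2CCN(c3ccc(F)c(Cl)c3)CC2)c1C(=O)c1ccc(Cl)cc1` gives 4.2%; the steps of a number 3.2 percentage points higher from compound 1 to compound 2 (within the scatter), a number 4.2 percentage points higher from compound 1 to compound 3 (within the scatter) and a number 1 percentage points higher from compound 2 to compound 3 (within the scatter) all stay within the scatter, so the three compounds are indistinguishable here. Compound 4 `Nc1scc(CN2CCN(c3ccc(Cl)c(Cl)c3)CC2)c1C(=O)c1ccc(Cl)cc1` is the next change at the same place: 3,4-dichlorophenyl in place of 4-(trifluoromethoxy)phenyl on an amine nitrogen in a ring. Within the data shown here, the steps that bear on it are the two earlier exchanges of the group on the amine nitrogen in the ring, from compound 1 to compound 2 and from compound 1 to compound 3, neither of which moved beyond the scatter. The expectation for compound 4 is therefore no step beyond the scatter, a number 3 percentage points higher from compound 1 to compound 4 (within the scatter). Compound 4 is estimated at 3%, in the range 0% to 12%.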

Compound 4, a percentage reported as activity, at one concentration (the size of the read-out at that concentration, not a potency): -1.2%
Compound 4: the middle estimate sits 4.2 percentage points above what was measured; measured number below the stated range.
By their numbers in this assay, from the lowest: compounds 4, 1, 2 and 3 (each within the scatter of the next).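

In this assay, compound 4 extends the exchanges on the amine nitrogen in a ring with no step beyond the scatter: a number 1.2 percentage points lower from compound 1 to compound 4 (within the scatter) and a number 4.4 percentage points lower from compound 2 to compound 4 (within the scatter) both leave the read-out unresolved. Within the data shown here, the first exchange on the aromatic ring itself, chloro in place of fluoro on an aromatic carbon, also gives no resolved change, with a number 5.4 percentage points lower from compound 3 to compound 4 (within the scatter) as its step. No available evidence bears on this result.

From the compounds shown here alone, whether a group without an aromatic ring, such as cyclohexyl or a chain ending in a carboxylic acid, would move the read-out beyond the scatter stays open.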